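Ring closure on the aminopurine nucleoside: compound 4 expected

The source may report more compounds than this note shows. Statements on the series, on what has been measured and on what is new or still open speak of the compounds shown alone.

Measured so far:
compound 1, `CNc1nc2c(SCc3ccccc3)ncnc2n1C1O[C@H](CO)[C@@H](O)[C@H]1O`, 28 nM
compound 2, `CCCNc1nc2c(SCc3ccccc3)ncnc2n1C1O[C@H](CO)[C@@H](O)[C@H]1O`, 5.3 nM
compound 3, `OC[C@H]1OC(n2c(NC3CCCC3)nc3c(SCc4ccccc4)ncnc32)[C@H](O)[C@@H]1O`, 0.64 nM

Compound 1 stands highest of the three numbers in an assay on cell membranes for binding affinity to Equilibrative nucleoside transporter 1 (Homo sapiens); on this read-out higher numbers stand for weaker inhibition and lower numbers for stronger inhibition. Its nearest neighbour is compound 2, reached by a 5.3-fold lower number from compound 1 to compound 2 (0.72 log units; beyond the scatter), and its furthest is compound 3, reached by a 44-fold lower number from compound 1 to compound 3 (1.64 log units; beyond the scatter); from compound 2 onward the step is an 8.3-fold lower number from compound 2 to compound 3 (0.92 log units; beyond the scatter).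

Compound 4, `OC[C@H]1OC(n2c(N3CCCC3)nc3c(SCc4ccccc4)ncnc32)[C@H](O)[C@@H]1O`, differs from compound 1 in one place: pyrrolidin-1-yl in place of methylamino on an aromatic carbon. The measured steps bear on this only partly. They show that enlarging the group on that nitrogen lowers the number, and that a five-membered ring carbon chain does so most. For the measured compounds named here, the data hold no step in which the nitrogen itself becomes part of a ring and loses its hydrogen, so the expectation rests on size alone and carries wide uncertainty. A modest downward step is expected, a 4.7-fold lower number from compound 1 to compound 4 (0.67 log units; beyond the scatter), smaller than the step to compound 3. The estimate for compound 4 is 6 nM, with a range from 1.5 nM to 25 nM.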

Compound 4, inhibition constant: 410 nM
Compound 4: middle estimate off by 68-fold (1.83 log units), on the low side, outside the stated range (above it).
By their numbers in this assay, from the lowest: compound 3; then compound 2; then compound 1; then compound 4.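

In this assay the pyrrolidin-1-yl group turns the trend at this position around: each earlier enlargement of the group on the nitrogen lowered the number, whereas this change brings a 15-fold higher number from compound 1 to compound 4 (1.17 log units; beyond the scatter) even though the entering group is the larger one. The gap is wider from the larger amino groups, with a 77-fold higher number from compound 2 to compound 4 (1.89 log units; beyond the scatter) and a 640-fold higher number from compound 3 to compound 4 (2.81 log units; beyond the scatter) for the change to pyrrolidin-1-yl, so size alone does not order these four compounds, and only compound 4 has no hydrogen-bond donor at this place. Nothing available here explains the reversal.

A dimethylamino group at this place would help separate the lost hydrogen on the nitrogen from the closed ring. As far as these compounds go, how a piperidin-1-yl or morpholin-4-yl group would compare with pyrrolidin-1-yl remains open.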